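A few compounds are considered here, and "the series" means these few. Any claim that something is new, unique, unknown or untested is made for them only; others in the source may bear on it.

Measured so far in a functional assay on HeLa cells (Homo sapiens) for cytotoxicity, in the presence of a further agent that is not named here; on this read-out higher numbers stand for weaker inhibition and lower numbers for stronger inhibition:
- Compound 1 `Clc1ccc(-c2cc(-c3ccsc3)nc(-c3ccco3)c2)o1`: > 50000 nM, a limit
- Compound 2 `Cc1ccccc1-c1cc(-c2ccc(Cl)o2)cc(-c2ccsc2)n1`: 9770 nM
- Compound 3 `Clc1ccc(-c2cc(-c3cccnc3)nc(-c3ccsc3)c2)o1`: > 50000 nM, a limit

Compound 3 gives > 50000 nM, which is a limit and not a number. It thus sits at the limit of > 50000 nM in this assay, at which 2 of the 3 values shown sit. Going by the values given here, only compound 2 has given a number so far.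

Compound 4 `Cc1ccc(-c2cc(-c3ccc(Cl)o3)cc(-c3ccsc3)n2)o1` carries 5-methylfuran-2-yl in place of pyridin-3-yl on an aromatic carbon, next to the ring nitrogen: 5-methylfuran-2-yl in place of pyridin-3-yl on an aromatic carbon.

Among the compounds with values here, two measured steps bear on this change. Replacing furan-2-yl with 2-methylphenyl gave an at least 5.1-fold lower number from compound 1 to compound 2 (0.70 log units; beyond the scatter), and replacing 2-methylphenyl with pyridin-3-yl gave an at least 5.1-fold higher number from compound 2 to compound 3 (0.70 log units; beyond the scatter). The remaining step, a step that the two limits leave unreadable from compound 1 to compound 3, tells nothing about size. Neither readable step involves 5-methylfuran-2-yl itself, so the guidance is indirect.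

A modest fall in the number is therefore expected in this assay, and compound 4 may well remain at the limit. The expected change is an at least 2.5-fold lower number from compound 3 to compound 4 (0.39 log units; beyond the scatter). For compound 4 the estimated value is 20000 nM, with an expected range of 7000 nM to 50000 nM.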

Compound 4, half-maximal inhibitory concentration: > 50000 nM
Compound 4 was reported as a limit (the forecaster's own chance of this, stated with the estimate: 40%); middle value at least 2.5-fold (0.39 log units) from the limit.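

In this assay, the change to 5-methylfuran-2-yl on this aromatic carbon, next to the ring nitrogen, loses what 2-methylphenyl gave, with an at least 5.1-fold higher number from compound 2 to compound 4 (0.70 log units; beyond the scatter). The steps from compound 3 and from compound 1 to compound 4 join two limits and cannot be read, so neither the swap for pyridin-3-yl nor the added methyl can be sized. Three different groups at this place now give no number, compound 2 alone going against that, and compound 4 joins compound 1 and compound 3 at one shared point: the limit of > 50000 nM in this assay, at which 3 of the 4 values shown sit.

As far as these compounds go, whether a plain phenyl, a 3-methylphenyl or a 2-methoxyphenyl at this place would also give a number stays open. From the compounds shown here alone, how far compound 1, compound 3 and compound 4 lie from one another also remains unknown.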